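Chloro for Ethyl at the Assay Limit

A few compounds are considered here, and "the series" means these few. Any claim that something is new, unique, unknown or untested is made for them only; others in the source may bear on it.

Compound 3 `CCc1ccc(S(=O)(=O)Nc2ccc(-c3nc4ccccc4o3)cc2)cc1` was tested in an assay on isolated protein for inhibition of malate dehydrogenase, mitochondrial (Sus scrofa), with stated times of 45 min and 30 min; on this read-out higher numbers stand for weaker inhibition and lower numbers for stronger inhibition. Compound 3 gives > 63000 nM, which is a limit of the assay, not a number. The two related compounds stand at the same place. Compound 1 `O=S(=O)(Nc1ccc2oc(-c3ccccc3)nc2c1)c1ccc(Cl)c(C(F)(F)F)c1` gives > 63000 nM, a limit. Compound 2 `Cc1cccc(S(=O)(=O)Nc2ccc3oc(-c4ccccc4)nc3c2)c1` gives > 63000 nM, also a limit. For the measured compounds named here, the one piece of evidence, (the limit of > 63000 nM in this assay, at which 3 of the 3 values shown sit), therefore describes every value so far. Compound 4 `O=S(=O)(Nc1ccc(-c2nc3ccccc3o2)cc1)c1ccc(Cl)cc1` has not yet been measured. It differs from compound 3 by chloro in place of ethyl on an aromatic carbon. With every measured value sitting at the limit, the expected step of a number no higher from compound 3 to compound 4 (the limit leaves the size open) is none beyond the scatter. Compound 4 is thus estimated at 63000 nM, with a range from 20000 nM to 200000 nM, and most probably reported again as a limit.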

Compound 4, half-maximal inhibitory concentration: > 63000 nM
Compound 4 was reported as a limit (the forecaster's own chance of this, stated with the estimate: 85%); the middle value lies on the limit itself.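

No step can be read between compound 3 and compound 4, as each is reported only as a limit. The compounds shown leave open which change to their structures, if any, would give a readable number: the limit of > 63000 nM in this assay, at which 4 of the 4 values shown sit.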